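Aryl amide swap in a sulfonamide series

The compounds below may be only part of what the source reports. "The series", "measured", "known", "first", "only" and "open" are said of these compounds alone.

Measured compounds:
Compound 1, `O=C(Nc1ccc(S(=O)(=O)Nc2ccccc2)cc1)c1ccc(I)cc1F`: 5130 nM
Compound 2, `O=C(Nc1ccc(S(=O)(=O)Nc2ccccc2)cc1)c1ccc(Cl)cc1Cl`: 457 nM

Among the measured compounds shown here, in a functional assay on HEK293 cells for agonist activity at probable G-protein coupled receptor 27 (Homo sapiens), read by a luciferase reporter and beta-arrestin recruitment, with a stated time of 10 min (on this read-out higher numbers stand for an effect only at larger amounts of compound and lower numbers for an effect already at smaller amounts), compound 2 gives the lowest of the two numbers known so far, with compound 1 as its only neighbour, an 11-fold lower number from compound 1 to compound 2 (1.05 log units; beyond the scatter). Compound 3, `O=C(Nc1ccc(S(=O)(=O)Nc2ccccc2)cc1)c1ccc(Cl)nc1F`, differs from compound 2 by 6-chloro-2-fluoropyridin-3-yl in place of 2,4-dichlorophenyl on a carbonyl carbon. For the measured compounds named here, the one measured step bears on it: the same amide-bound aryl position was changed there, and the change was large. A step of similar size, and possibly in the other direction, is therefore expected here, so that from compound 2 to compound 3 the number is estimated to move by a 2.6-fold higher number from compound 2 to compound 3 (0.42 log units; beyond the scatter). Compound 3 is expected to give 1200 nM, within 300 nM to 5000 nM.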

Compound 3, half-maximal effective concentration: 2290 nM
Beside the measured number, compound 3's estimate is 1.9-fold (0.28 log units) below it, within the range that was stated.
By their numbers in this assay, from the lowest: compound 2; then compound 3; then compound 1.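

In this assay, a ring with a hetero atom on the carbonyl carbon keeps a measurable response, but the change to 6-chloro-2-fluoropyridin-3-yl gives a 5.0-fold higher number from compound 2 to compound 3 (0.70 log units; beyond the scatter). The same group compared with 2-fluoro-4-iodophenyl gives a 2.2-fold lower number from compound 1 to compound 3 (0.35 log units; beyond the scatter), so this position separates all three aryl groups, with 2,4-dichlorophenyl giving the lowest number. No measurement available here accounts for either step.

The compounds shown do not separate the ring nitrogen from the change of halogens, as both change together in compound 3. On these data alone, how a methoxy group or an amine on this aryl group would read also stays open.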